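The source may hold more compounds than are shown below. What is called first, only, known or untested is meant among the compounds shown, and "the series" means these compounds.

Compound 1 `CCOc1ccc(/C=C(\C(=O)c2ccc(Cl)cc2)S(=O)(=O)Cc2ccc(F)cc2)cc1OC`: 50000 nM
Compound 2 `CCOc1ccc(/C=C(/Sc2ccc(C)cc2)C(=O)c2ccc(Br)cc2)cc1OC`: 50000 nM

In a functional assay on DU-145 cells (Homo sapiens) for inhibition, read by trypan blue exclusion, with a stated time of 96 h (a lower number here means a stronger inhibitor of growth, a higher number a weaker inhibitor of growth), compound 2 gives 50000 nM, level with compound 1 at the digits shown. Compound 3 `CCOc1ccc(/C=C(/Sc2ccc(C)cc2)C(=O)c2ccc(Cl)cc2)cc1OC` differs from compound 2 in one place: chloro in place of bromo on an aromatic carbon, para to a large group. Within the data shown here, no measured pair here shows this swap, so the expectation rests on the structural change alone: no step beyond the scatter in this assay, in either direction. The expected change a 1.1-fold lower number from compound 2 to compound 3 (0.05 log units; within the scatter) is small. For compound 3 the estimate is 45000 nM, with an expected range of 15000 nM to 70000 nM.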

Compound 3, concentration for 50% growth inhibition: 25000 nM
Compound 3: the middle estimate sits 1.8-fold (0.26 log units) above what was measured, and the stated range covers the measured number.
By their numbers in this assay, from the lowest: compounds 3, 1 and 2 (each within the scatter of the next).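

Chloro in place of bromo on this aromatic carbon gives a 2.0-fold lower number from compound 2 to compound 3 (0.30 log units; within the scatter) in this assay, so this first one-place exchange at the position produces no step that stands clear of repeat measurements. Putting (4-methylphenyl)sulfanyl in place of (4-fluorobenzyl)sulfonyl gives a 2.0-fold lower number from compound 1 to compound 3 (0.30 log units; within the scatter), which is likewise no clear step. No supporting measurement is available to explain either result.

Only halogens have been compared at this aromatic carbon. From the compounds shown here alone, whether an amine or a carboxylic acid there would give a clear step remains open.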